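A few compounds are considered here, and "the series" means these few. Any claim that something is new, unique, unknown or untested is made for them only; others in the source may bear on it.

Compound 1 `COc1ccc2ncc(S(=O)(=O)c3ccc(OC)c(OC)c3)c(N3CCC(C)CC3)c2c1`: -3%
Compound 2 `CC1CCN(c2c(S(=O)(=O)c3ccc(F)cc3)cnc3c(F)cccc23)CC1`: 26%
Compound 3 `COc1ccc(S(=O)(=O)c2cnc3ccc(Cl)cc3c2N2CCC(C)CC2)cc1OC`: 61%

In an assay on isolated protein for displacement of a labelled ligand from metabotropic glutamate receptor 5 (Homo sapiens), with a stated time of 60 min, tested at 1 uM (on this read-out lower numbers stand for less inhibition and higher numbers for more inhibition at the one concentration tested (going by the name of the read-out)), compound 1 gives the lowest of the three numbers; compound 2 gives 26% and compound 3 gives 61%, both beyond the scatter above it. Compound 4 `COc1ccc2ncc(S(=O)(=O)c3ccc(C)c(Cl)c3)c(N3CCC(C)CC3)c2c1` differs from compound 1 in one place: 3-chloro-4-methylphenyl in place of 3,4-dimethoxyphenyl on a sulfonyl sulfur. Within the data shown here, no measured step alters this group on the sulfonyl sulfur. Among the measured compounds shown here, the one measured step, a number 64 percentage points higher from compound 1 to compound 3 (beyond the scatter), also brings a chlorine into the molecule, though at a different place, and it was large. Because of a number 64 percentage points higher from compound 1 to compound 3 (beyond the scatter) an increase in this assay is expected for compound 4, of uncertain size since the place of change is not the same. Compound 4 is therefore estimated at 35% (range 5% to 65%), an expected step of a number 38 percentage points higher from compound 1 to compound 4 (beyond the scatter).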

Compound 4, a percentage reported as inhibition, at one concentration (the size of the read-out at that concentration, not a potency): 85%
Beside the measured number, compound 4's estimate is 50 percentage points below it, and the stated range ends below it.
By their numbers in this assay, from the lowest: compound 1; then compound 2; then compound 3; then compound 4.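

In this assay, the group on the sulfonyl sulfur proves able to carry a large change on its own: 3-chloro-4-methylphenyl in place of 3,4-dimethoxyphenyl gives a number 88 percentage points higher from compound 1 to compound 4 (beyond the scatter). Among these compounds, until now, the only measured step had been made elsewhere on the shared core. Nothing available explains this step.

Going by these compounds, the chlorine and the methyl enter together, so their separate shares remain open. Also open, on these data alone, is how a trifluoromethyl or a nitrile on this aromatic ring would compare, and whether this group and the chloro of compound 3 would add up.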